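Swapping the dichlorophenyl of compound 1 for methoxyphenyl

The source may report more compounds than this note shows. Statements on the series, on what has been measured and on what is new or still open speak of the compounds shown alone.

Among the measured compounds shown here, the three compounds measured so far share one core and were tested in a functional assay on CCRF-CEM cells (Homo sapiens) for inhibition, read by sulforhodamine B assay, with a stated time of 48 h; a lower number here means that less compound is tolerated, a higher number that more compound is tolerated. For the measured compounds named here, compound 1, `Nc1cc(N)c2nc(-c3ccccc3)c(NCc3ccc(Cl)c(Cl)c3)nc2c1`, gives 17400 nM in this assay, and that is the only actual number among the three. Compound 2, `Nc1cc(N)c2nc(-c3ccccc3)c(Sc3ccc(Cl)c(Cl)c3)nc2c1`, carries a 3,4-dichlorophenyl on a sulfur instead of on the aminomethyl group; in this assay compound 2 gives only a limit, < 100000 nM. Compound 3, `CCOC(=O)[C@H](CCC(=O)O)NC(=O)c1ccc(CNc2nc3cc(N)cc(N)c3nc2-c2ccccc2)cc1`, bears a longer side chain ending in a glutamate ester; in this assay compound 3 likewise gives only a limit, < 100000 nM. So two of the three values sit at the limit of < 100000 nM in this assay, at which 2 of the 3 values shown sit, and compound 1 alone stands at a measured number.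

Compound 4, `COc1ccc(CNc2nc3cc(N)cc(N)c3nc2-c2ccccc2)cc1`, differs from compound 1 in one place: 4-methoxyphenyl in place of 3,4-dichlorophenyl on a saturated chain carbon bound to a nitrogen on an aromatic ring. Going by the values given here, no measured pair in this set shows what such an exchange does, so the expectation rests on compound 1 alone. Compound 4 is estimated to keep roughly the potency of compound 1, with a step from compound 1 to compound 4 of a 1.7-fold higher number from compound 1 to compound 4 (0.24 log units; within the scatter), which would lie at or near the usual scatter. Compound 4 is therefore expected to give about 30000 nM in this assay, within a range from 10000 nM to 100000 nM.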

Compound 4, concentration lethal to 50% of the cells: < 100000 nM
Compound 4: no number, only a limit; the forecaster's own chance of this, stated with the estimate: 30%; the middle value lies beyond the limit too.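

Compound 4 gives only a limit in this assay, so the size of the step between compound 1 and compound 4 cannot be read, and the limit is a shared one: the limit of < 100000 nM in this assay, at which 3 of the 4 values shown sit.

The compounds shown leave open whether 4-methoxyphenyl in place of 3,4-dichlorophenyl changes the number in this assay at all, and in which direction.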